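The source may report more compounds than this note shows. Statements on the series, on what has been measured and on what is new or still open speak of the compounds shown alone.

In an ADME assay on Vero cells (Chlorocebus sabaeus) for cytotoxicity, read by resazurin assay, with a stated time of 72 h (on this read-out higher numbers stand for weaker inhibition and lower numbers for stronger inhibition), compound 2 (`O=C(CCN1CCN(c2ccc(F)cc2)CC1)c1ccc(F)c(F)c1`) gives 385000 nM and compound 1 (`O=C(CCN1CCN(c2ccc(Cl)cc2)CC1)c1ccc(F)c(Br)c1`) gives 206000 nM, two values within the scatter of each other. Compound 3 (`O=C(CCN1CCN(c2ccc(Cl)cc2)CC1)c1ccc(F)c(F)c1`) has chloro in place of fluoro on an aromatic carbon of compound 2, para to a large group: chloro in place of fluoro on an aromatic carbon. Among the measured compounds shown here, no measured pair shows this change alone, but compound 1, which also carries 4-chlorophenyl, gives 206000 nM, so no step beyond the scatter is expected in this assay. The expected step is a 1.5-fold lower number from compound 2 to compound 3 (0.17 log units; within the scatter). For compound 3 the estimated value is 260000 nM, with an expected range of 130000 nM to 500000 nM.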

Compound 3, half-maximal inhibitory concentration: 86200 nM
Beside the measured number, compound 3's estimate is 3.0-fold (0.48 log units) above it; measured number below the stated range.
By their numbers in this assay, from the lowest: compound 3; then compounds 1 and 2 (each within the scatter of the next).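

In this assay the change from 4-fluorophenyl to 4-chlorophenyl brings a 4.5-fold lower number from compound 2 to compound 3 (0.65 log units; beyond the scatter) and so moves the number beyond the scatter, which compounds 1 and 2 alone could not show. With 4-chlorophenyl kept, fluoro in place of bromo on an aromatic carbon brings a 2.4-fold lower number from compound 1 to compound 3 (0.38 log units; beyond the scatter) as well, so this second place also affects the number. Nothing at hand accounts for either step.

The compounds shown leave open whether the chloro step holds with bromo in the other place. They also leave open what a methoxy group or an amine would give in place of the chloro.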